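This account rests on a few compounds, and the source may have more. Where it says the series, first, only, none or still open, it means among the compounds named here.

Within the data shown here, in a functional assay on Bel7402/5-FU cells (Homo sapiens) for antiproliferative activity, read by MTT assay, with a stated time of 72 h (a higher number here means a weaker inhibitor, a lower number a stronger inhibitor), compound 1 `C=C1C(=O)O[C@H]2[C@H]1CC/C(COC(=O)Cn1cc(F)c(=O)n(Cc3ccccc3)c1=O)=C\CC[C@@]1(C)O[C@@H]21` gives 4270 nM and so has the lower of the two numbers so far. Compound 2 `C=C1C(=O)O[C@H]2[C@H]1CC/C(Cn1cc(Cn3cc(F)c(=O)n(Cc4ccccc4)c3=O)nn1)=C\CC[C@@]1(C)O[C@@H]21` gives 8840 nM and that gap lies beyond the usual scatter. Compound 3 `C=C1C(=O)O[C@H]2[C@H]1CC/C(COC(=O)Cn1cc(F)c(=O)n(Cc3ccc([N+](=O)[O-])cc3)c1=O)=C\CC[C@@]1(C)O[C@@H]21` differs from compound 1 in one place (nitro in place of hydrogen on an aromatic carbon) with nitro in place of hydrogen on an aromatic carbon, para to a large group, so benzyl becomes 4-nitrobenzyl. Among the measured compounds shown here, no measured pair shows this change, so in this assay the expected 1.1-fold lower number from compound 1 to compound 3 (0.05 log units; within the scatter) is no step beyond the scatter. Compound 3 is expected to give 3800 nM within an estimated range from 1500 nM to 9500 nM once measured.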

Compound 3, half-maximal inhibitory concentration: 4340 nM
Compound 3: the middle estimate sits 1.1-fold (0.06 log units) below what was measured; low and high end bracket the measured number.
By their numbers in this assay, from the lowest: compounds 1 and 3 (each within the scatter of the next); then compound 2.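

In this assay, nitro in place of hydrogen on an aromatic carbon, para to a large group, gives a 1.0-fold higher number from compound 1 to compound 3 (0.01 log units; within the scatter). At this position, then, benzyl and 4-nitrobenzyl cannot be told apart in this read-out, even though the change adds 3 heavy atoms. No supporting evidence is available to explain this result. One group at one position cannot show whether an amine or a carboxylic acid would also leave the number unchanged. On these data alone, whether the same change would behave alike on compound 2 also remains open.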